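A few compounds are considered here, and "the series" means these few. Any claim that something is new, unique, unknown or untested is made for them only; others in the source may bear on it.

Compound 1 `COc1cccc(OC)c1/C=N/NC(=O)c1ccncc1` and compound 2 `COc1cccc(OC)c1/C=N/N(C(=O)c1ccccc1)C(=O)c1ccncc1` share one core, while compound 3 `CSc1ccc(/C=N/N(C(=O)c2ccccc2)C(=O)c2ccncc2)cc1` is built on a second core; the difference between the two cores is not broken down here. In an ADME assay on HEL cells (Homo sapiens) for cytotoxicity (a higher number here means that more compound is tolerated, a lower number that less compound is tolerated), compound 1 gives > 100 ug/mL, a limit of the assay rather than a number. Compound 2 also reaches only a limit, > 100 ug/mL, in this assay. Compound 3 likewise stops at a limit, > 100 ug/mL. The change from compound 2 to compound 1 is hydrogen in place of benzoyl on an amide-type nitrogen; its step, a step that the two limits leave unreadable from compound 2 to compound 1, stays unreadable because of the limit of > 100 ug/mL in this assay, at which 3 of the 3 values shown sit. Compound 4 `CSc1ccc(/C=N/NC(=O)c2ccncc2)cc1` is not yet measured. It differs from compound 3 by hydrogen in place of benzoyl on an amide-type nitrogen, the same change as from compound 2 to compound 1, made at the same kind of place. No size for this change can be taken from the measured pair. The expectation for compound 4 therefore rests on compound 3 and its limit in this assay. Compound 4 is expected to show a step of a number no higher from compound 3 to compound 4 (the limit leaves the size open). Compound 4 is estimated at 100 ug/mL, with a range from 50 ug/mL to 200 ug/mL, most likely again a limit.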

Compound 4, minimum cytotoxic concentration: > 100 ug/mL
Compound 4 ended at the assay's limit; the forecaster's own chance of this, stated with the estimate: 85%; the middle value sits exactly at the limit.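

No step can be read between compound 3 and compound 4, nor between compound 2 and compound 1, because the values of all four compounds are limits rather than numbers: the limit of > 100 ug/mL in this assay, at which 4 of the 4 values shown sit.

The compounds shown leave open how much hydrogen in place of benzoyl on the amide-type nitrogen changes the result in this assay, or whether it changes it at all.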